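Fluorinated Aryl in Place of Dimethoxyphenyl on the Thiazolidinone

The compounds below may be only part of what the source reports. "The series", "measured", "known", "first", "only" and "open" are said of these compounds alone.

Three compounds sharing one core were tested in a functional assay on U2OS cells (Homo sapiens) for inhibition, read by CCK-8 assay, with a stated time of 72 h, tested at 1 uM; a lower number here means less inhibition, a higher number more inhibition at the concentration tested (going by the name of the read-out). Compound 1 `COc1ccc(C)cc1N1C(=O)CSC1c1cccc(C(=O)NCCCCc2ccccc2)c1` gives 30%. Compound 2 `COc1ccc(OC)c(N2C(=O)CSC2c2cccc(C(=O)NCCCCc3ccccc3)c2)c1` gives 1%. Compound 3 `COc1cccc(OC)c1N1C(=O)CSC1c1cccc(C(=O)NCCCCc2ccccc2)c1` gives 41%, the highest of the three numbers; its nearest neighbour is compound 1 and its furthest is compound 2. The measured steps show a number 29 percentage points lower from compound 1 to compound 2 (beyond the scatter), a number 11 percentage points higher from compound 1 to compound 3 (beyond the scatter) and a number 40 percentage points higher from compound 2 to compound 3 (beyond the scatter).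

Compound 4 `CC(F)(F)c1cccc(N2C(=O)CSC2c2cccc(C(=O)NCCCCc3ccccc3)c2)c1` differs from compound 3 in this way: a group of 10 heavy atoms (8 carbon, 2 fluorine; one six-membered aromatic ring of carbon only) in place of a group of 10 heavy atoms (8 carbon, 2 oxygen; one six-membered aromatic ring of carbon only), on an amide-type nitrogen in a ring. The two steps that bear on it are those that change the aryl group on the amide-type nitrogen in the ring, from compound 1 and from compound 2 to compound 3, and they range from modest to large, with the arrangement of the two methoxy groups alone accounting for the large one. Within the data shown here, no measured step removes both acceptors or introduces fluorine, so the direction is uncertain, and a drop is considered somewhat more likely than a rise. Compound 4 is therefore expected at 20%, within -5% to 45%, which would mean an expected step of a number 21 percentage points lower from compound 3 to compound 4 (beyond the scatter).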

Compound 4, a percentage reported as inhibition, at one concentration (the size of the read-out at that concentration, not a potency): 24%
Estimate against measurement, compound 4: 4 percentage points below, and the stated range covers the measured number.
By their numbers in this assay, from the lowest: compound 2; then compounds 4 and 1 (each within the scatter of the next); then compound 3.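

Replacing the 2,6-dimethoxyphenyl with an aryl group that carries fluorine and has no hydrogen-bond acceptors gives a number 17 percentage points lower from compound 3 to compound 4 (beyond the scatter) in this assay and so loses part of the reading but not all of it. On this amide-type nitrogen, methoxy groups are therefore not needed for inhibition to be seen at the concentration tested: the same kind of swap gives a number 23 percentage points higher from compound 2 to compound 4 (beyond the scatter) and a number 6 percentage points lower from compound 1 to compound 4 (within the scatter) in this assay and leaves the fluorinated aryl group level with the 2-methoxy-5-methylphenyl group. Nothing measured here accounts for these differences.

The compounds shown leave open whether the reading follows the fluorine atoms or only the absence of the methoxy groups, and how an unsubstituted phenyl or a pyridine ring would read at this position. They also leave open whether an amine or a carboxylic acid on this aryl group would raise or lower the number.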